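The compounds below may be only part of what the source reports. "The series", "measured", "known", "first", "only" and "open" are said of these compounds alone.

Working notes on a series sharing one core. Compound 1 `CN(C)[C@H]1C[C@H](c2c[nH]c3ccc(C(=O)NCc4ccccc4)cc32)C1` gives 141 nM in an assay on CHO-K1 cells for binding affinity to 5-hydroxytryptamine receptor 1D (Homo sapiens); on this read-out higher numbers stand for weaker inhibition and lower numbers for stronger inhibition. Compound 2 `Cc1nc(Cc2ccc3[nH]cc([C@H]4C[C@H](N(C)C)C4)c3c2)n[nH]1` gives 2040 nM in this assay, the second-highest of the three numbers; compound 3 `CN(C)[C@H]1C[C@H](c2c[nH]c3ccc(CN4C(=O)NC(C)(C)C4=O)cc32)C1` gives 3090 nM, which sits within the scatter of compound 2, whereas the gap between compound 1 and compound 2 lies beyond it. Compound 4 `Cc1noc(-c2ccc3[nH]cc([C@H]4C[C@H](N(C)C)C4)c3c2)n1` is not yet measured and differs from compound 2 in one place: 3-methyl-1,2,4-oxadiazol-5-yl in place of (5-methyl-1H-1,2,4-triazol-3-yl)methyl on an aromatic carbon. Among the compounds with values here, no measured pair shows this change, so its size in this assay rests on judgment; a moderately lower number is expected, near the edge of the scatter, as the step of a 2.0-fold lower number from compound 2 to compound 4 (0.31 log units; beyond the scatter). Compound 4 is therefore estimated at 1000 nM in this assay, with a range from 300 nM to 4000 nM.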

Compound 4, half-maximal inhibitory concentration: 562 nM
Compound 4: the middle estimate sits 1.8-fold (0.25 log units) above what was measured, within the range that was stated.
By their numbers in this assay, from the lowest: compound 1; then compound 4; then compounds 2 and 3 (each within the scatter of the next).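

With 3-methyl-1,2,4-oxadiazol-5-yl in place of (5-methyl-1H-1,2,4-triazol-3-yl)methyl, this assay gives the first step read at this aromatic carbon, a 3.6-fold lower number from compound 2 to compound 4 (0.56 log units; beyond the scatter), so the number here does respond to the group carried. The change is not a single one, as the group entering has 0 hydrogen-bond donors against 1 hydrogen-bond donor in the group leaving, and its ring sits on the aromatic carbon without the methyl link. Nothing available accounts for the step. The compounds shown leave open whether (3-methyl-1,2,4-oxadiazol-5-yl)methyl on this carbon would hold the lower number, which would separate the ring change from the loss of the link.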